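Ethoxy in place of methyl on the carbonyl carbon

The source may hold more compounds than are shown below. What is called first, only, known or untested is meant among the compounds shown, and "the series" means these compounds.

compound 1 `O=C(CSC(=S)N[C@H]1CCOC1=O)Nc1ccc(Cl)cc1` gives 50300 nM in a functional assay on MCF7 cells (Homo sapiens) for cytotoxicity, read by MTT assay, with a stated time of 72 h; a higher number here means a weaker inhibitor, a lower number a stronger inhibitor
compound 2 `O=C(CSC(=S)N[C@H]1CCOC1=O)Nc1ccc(O)cc1` gives only a limit, > 128000 nM
compound 3 `CC(=O)c1ccc(NC(=O)CSC(=S)N[C@H]2CCOC2=O)cc1` gives only a limit, > 128000 nM

Compound 3 sits at the limit of > 128000 nM in this assay, at which 2 of the 3 values shown sit, so its own number is not known. The step of an at least 2.5-fold higher number from compound 1 to compound 3 (0.40 log units; beyond the scatter) shows acetyl in place of chloro weakening the compound at least modestly, while the step that the two limits leave unreadable from compound 2 to compound 3 cannot be read. Compound 4 `CCOC(=O)c1ccc(NC(=O)CSC(=S)N[C@H]2CCOC2=O)cc1` differs from compound 3 by ethoxy in place of methyl on a carbonyl carbon. Going by the values given here, no measured step touches this position, and the only guide is that compound 3 already rests at the limit. Compound 4 is therefore expected to remain near that limit, with a step that the limit leaves unreadable from compound 3 to compound 4 as the expected step, nothing beyond the scatter. The value of compound 4 in this assay is estimated at 150000 nM, between 60000 nM and 400000 nM.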

Compound 4, half-maximal inhibitory concentration: 60300 nM
Estimate against measurement, compound 4: 2.5-fold (0.40 log units) above, within the range that was stated.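

In this assay, ethoxy in place of methyl on the carbonyl carbon gives an at least 2.1-fold lower number from compound 3 to compound 4 (0.32 log units; beyond the scatter), so this small extension does register at this position. The step out of compound 3 starts from a limit, not a number: the limit of > 128000 nM in this assay, at which 2 of the 4 values shown sit. Ethoxycarbonyl in place of hydroxy gives an at least 2.1-fold lower number from compound 2 to compound 4 (0.32 log units; beyond the scatter), while ethoxycarbonyl in place of chloro gives a 1.2-fold higher number from compound 1 to compound 4 (0.08 log units; within the scatter), which leaves those two groups level.

As far as these compounds go, whether a longer chain on the carbonyl carbon would move the value further remains open. So does the effect of an amine or a carboxylic acid on that aromatic carbon.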